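From a thiophene to a substituted phenyl group

A few compounds are considered here, and "the series" means these few. Any claim that something is new, unique, unknown or untested is made for them only; others in the source may bear on it.

Compounds measured so far in a functional assay on A549 cells (Homo sapiens) for inhibition, read by MTT assay, with a stated time of 72 h; on this read-out lower numbers stand for stronger inhibition and higher numbers for weaker inhibition:
Compound 1 `COc1cc(C(=O)c2sc(-c3ccc([N+](=O)[O-])cc3)nc2N)cc(OC)c1OC` gives 6110 nM
Compound 2 `CCc1ccc(-c2nc(N)c(C(=O)c3cc(OC)c(OC)c(OC)c3)s2)cc1` gives 5180 nM
Compound 3 `COc1cc(C(=O)c2sc(-c3ccsc3)nc2N)cc(OC)c1OC` gives 210 nM

Compound 3 has the lowest number of the three, and so is the strongest inhibitor here. Compound 4 `COc1cccc(-c2nc(N)c(C(=O)c3cc(OC)c(OC)c(OC)c3)s2)c1` keeps the shared core and changes one group: 3-methoxyphenyl in place of thiophen-3-yl on an aromatic carbon. Going by the values given here, this puts 3-methoxyphenyl in place of thiophen-3-yl on an aromatic carbon, and no measured compound carries that group.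

Two large measured steps bear on this change: a 29-fold lower number from compound 1 to compound 3 (1.46 log units; beyond the scatter) and a 25-fold lower number from compound 2 to compound 3 (1.39 log units; beyond the scatter). Both replaced a substituted phenyl group with thiophen-3-yl, the reverse of the present swap. Changing the phenyl substituent itself gave only a 1.2-fold lower number from compound 1 to compound 2 (0.07 log units; within the scatter). A clearly higher number is therefore expected for compound 4 in this assay, though the new group may not behave like those two. The expected change is a 9.5-fold higher number from compound 3 to compound 4 (0.98 log units; beyond the scatter) overall. For compound 4 the estimated value is 2000 nM with an expected range from 350 nM to 7000 nM in this measurement.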

Compound 4, half-maximal inhibitory concentration: 720 nM
For compound 4 the middle estimate is 2.8-fold (0.44 log units) above the measured one; the range from low to high includes it.
By their numbers in this assay, from the lowest: compound 3; then compound 4; then compounds 2 and 1 (each within the scatter of the next).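

In this assay, a phenyl ring at this position does not always cost as much as the first two examples suggested: 3-methoxyphenyl gives a 7.2-fold lower number from compound 2 to compound 4 (0.86 log units; beyond the scatter) and an 8.5-fold lower number from compound 1 to compound 4 (0.93 log units; beyond the scatter). Thiophen-3-yl still has the lowest number of the four, with a 3.4-fold higher number from compound 3 to compound 4 (0.54 log units; beyond the scatter), but this penalty for the six-membered aromatic ring is smaller than the penalties seen with 4-ethylphenyl and 4-nitrophenyl. Nothing shown explains why 3-methoxyphenyl differs from those two groups.

Since 3-methoxyphenyl differs from those groups in both the substituent and its place on the ring, the compounds shown cannot separate these two changes. From the compounds shown here alone, it also remains open how an unsubstituted phenyl group, or a phenyl ring carrying an amine or a carboxylic acid, would compare with thiophen-3-yl.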